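A Small Ester Change Near the Assay Limit

The source may hold more compounds than are shown below. What is called first, only, known or untested is meant among the compounds shown, and "the series" means these compounds.

Of the compounds shown here, three have been tested in an ADME assay on H1-HeLa cells (Homo sapiens) for cytotoxicity, read by MTT assay, with a stated time of 3 days; a higher number here means that more compound is tolerated, a lower number that less compound is tolerated. Compound 1 (`CCOC(=O)c1cc2ccc(Oc3ccnc(C(=O)NC)c3)c(Cl)c2s1`) gives > 100000 nM, which is a limit of the assay and not a number. Compound 2 (`CCOC(=O)c1sc2cc(Oc3ccccc3)ccc2c1C`) gives > 100000 nM, again only a limit. Among the measured compounds shown here, compound 3 (`CNC(=O)c1cc(Oc2ccc3ccc(C(=O)OC)cc3c2)ccn1`) gives 53500 nM, the only actual number of the three.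

Compound 4 (`CCOC(=O)c1ccc2ccc(Oc3ccnc(C(=O)NC)c3)cc2c1`) turns the methoxycarbonyl of compound 3 into ethoxycarbonyl: methyl in place of hydrogen on a saturated chain carbon bound to an oxygen next to a carbonyl group. This is methyl in place of hydrogen on a saturated chain carbon bound to an oxygen next to a carbonyl group. For the measured compounds named here, no two tested compounds differ in just one place, so no direct measure of such a step exists. Compound 1 and compound 2 also carry ethoxycarbonyl on different cores, and they account for (the limit of > 100000 nM in this assay, at which 2 of the 3 values shown sit). This gives a weak hint towards more compound being tolerated. The estimated step of a 1.2-fold higher number from compound 3 to compound 4 (0.08 log units; within the scatter) is expected to stay within the usual scatter. For compound 4 the expected value is 65000 nM, with an estimated range from 30000 nM to 100000 nM.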

Compound 4, half-maximal cytotoxic concentration: 20800 nM
Compound 4: middle estimate off by 3.1-fold (0.49 log units), on the high side, and the stated range ends above it.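

Adding one methyl to the ester, which turns methoxycarbonyl into ethoxycarbonyl, gives a 2.6-fold lower number from compound 3 to compound 4 (0.41 log units; beyond the scatter), so less compound is tolerated. Among the compounds shown here, this is the first step between two compounds that differ in one place, and it shows that this saturated chain carbon is not indifferent to even a single added carbon. Compound 1 and compound 2 also carry ethoxycarbonyl on different cores, but their results are limits of the assay and not numbers, so they could not show this: the limit of > 100000 nM in this assay, at which 2 of the 4 values shown sit.

The compounds shown leave open whether a longer chain such as propyl would lower the number further, and how a carboxylic acid in place of the ester would compare. A single step on one core also cannot say why the number moves, or whether the same change would act alike on other cores.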